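The source may report more compounds than this note shows. Statements on the series, on what has been measured and on what is new or still open speak of the compounds shown alone.

Measured compounds:
compound 1 `Nc1ccccc1NC(=O)c1ccc(CSC(=S)N2CCN(Cc3ccccn3)CC2)cc1`, in a functional assay on MGC-803 cells (Homo sapiens) for antiproliferative activity, read by CCK-8 assay, with a stated time of 72 h, tested at 8 uM (a lower number here means a weaker effect, a higher number a stronger effect of the compound at the concentration tested), compound 1 gives 65.2%.
compound 2 `Nc1ccccc1NC(=O)c1ccc(CSC(=S)N2CCc3ccccc32)cc1`, in this assay compound 2 gives 87%.

Of the two numbers available, compound 2 stands highest, and its nearest neighbour, compound 1, sits a good way lower, a gap that lies beyond the usual scatter of this measurement. Both compounds share the same core, and they differ only in the group carried on the thiocarbonyl carbon, so the two values show that this position matters for the read-out.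

Compound 3 `CC1CCCCN1C(=S)SCc1ccc(C(=O)Nc2ccccc2N)cc1` has not yet been measured. It is reached from compound 2 by one change: 2-methylpiperidin-1-yl in place of 2,3-dihydro-1H-indol-1-yl on a thiocarbonyl carbon. For the measured compounds named here, no step between measured compounds of this exact kind is available, so the expectation rests only on the two numbers above. Because compound 2 gives 87% with a bicyclic group at this position, while compound 1 with a different saturated ring system gives 65.2%, a modest downward step a number 11 percentage points lower from compound 2 to compound 3 (beyond the scatter) is expected, possibly no larger than the scatter. Compound 3 is therefore expected to give about 76%, within a range from 58% to 90%.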

Compound 3, a percentage reported as inhibition, at one concentration (the size of the read-out at that concentration, not a potency): 86.9%
For compound 3 the middle estimate is 10.9 percentage points below the measured one, within the range that was stated.
By their numbers in this assay, from the lowest: compound 1; then compounds 3 and 2 (each within the scatter of the next).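

Putting 2-methylpiperidin-1-yl in place of 2,3-dihydro-1H-indol-1-yl on a thiocarbonyl carbon gives a number 0.1 percentage points lower from compound 2 to compound 3 (within the scatter) in this assay, so at this concentration the position accepts a single six-membered non-aromatic ring as well as the two rings of the group it replaces, and a six-membered aromatic ring in this group is not needed for the read-out. Compound 1 gives 65.2% and has a non-aromatic ring on the thiocarbonyl carbon. Compound 3 also has a non-aromatic ring there and gives 86.9%. Nothing in the data shown accounts for why the two groups read alike.

The single concentration leaves open whether compound 2 and compound 3 would also match in potency. From the compounds shown here alone, it also remains open how the position responds to unsubstituted piperidin-1-yl, which would show what the methyl group contributes, or to morpholin-4-yl or an open-chain diethylamino group.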